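Cyclohexyl to hydrogen on the shared core, a lipophilicity step

The compounds below may be only part of what the source reports. "The series", "measured", "known", "first", "only" and "open" are said of these compounds alone.

Measured compounds:
compound 1, `CCc1ccc(N(CC(C)C)S(=O)(=O)c2ccc3c(c2)C(OC2CCCCC2)CC(C2CCOCC2)O3)cc1` — 6.28
compound 2, `CCc1ccc(N(C2COC2)S(=O)(=O)c2ccc3c(c2)C(O)CC(C2CCOCC2)O3)cc1` — 2.63

Of the compounds shown here, two have been measured in a physicochemical assay for lipophilicity, at pH 7.4; a higher number here means a more lipophilic compound, a lower number a more polar compound. Compound 1 gives 6.28, the higher of the two numbers. Compound 2 gives 2.63, a number well below that of compound 1, beyond the scatter; the two compounds differ in more than one place, so their gap cannot be assigned to a single change.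

The piece follows the step from compound 1 to compound 3, `CCc1ccc(N(CC(C)C)S(=O)(=O)c2ccc3c(c2)C(O)CC(C2CCOCC2)O3)cc1`, which has not yet been measured in this assay. The change is hydrogen in place of cyclohexyl on an oxygen on a saturated carbon. Compound 3 keeps the isobutyl of compound 1 and shares the hydroxy of compound 2.

Within the data shown here, no step between measured compounds is known, so the size must be expected from the structures. Six carbons leave and a hydrogen enters, and compound 2, which also carries a hydroxy, sits at 2.63; a large downward step is therefore expected, well beyond the scatter, estimated at a number 2.48 log units lower from compound 1 to compound 3 (beyond the scatter). For compound 3 the expected value is 3.8, within 3 to 4.6.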

Compound 3, distribution coefficient: 4.12
Estimate against measurement, compound 3: 0.32 log units below; low and high end bracket the measured number.
By their numbers in this assay, from the lowest: compound 2; then compound 3; then compound 1.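

In this assay, among these compounds, hydrogen in place of cyclohexyl on an oxygen on a saturated carbon gives a number 2.16 log units lower from compound 1 to compound 3 (beyond the scatter), the first change at this position that can be read on its own, with everything else in the molecule held constant. Compound 3 also connects the two earlier compounds: isobutyl in place of oxetan-3-yl on a sulfonamide nitrogen gives a number 1.49 log units higher from compound 2 to compound 3 (beyond the scatter), so the distance between the printed values of compound 1 and compound 2 now runs through two single changes, each of them large. No measurement bearing on the origin of either step is available, so the data record their size and direction without explaining them.

The compounds shown pair cyclohexyloxy only with isobutyl on the sulfonamide nitrogen, so it remains open whether the step at the oxygen would keep its size with oxetan-3-yl in that place, and whether the two changes simply add up. Also open, going by these compounds, is where a small ether such as methoxy, or an amine on that same saturated carbon, would fall.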